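A few compounds are considered here, and "the series" means these few. Any claim that something is new, unique, unknown or untested is made for them only; others in the source may bear on it.

Working notes on the series. Within the data shown here, in a functional assay on B16-F10 cells (Mus musculus) for inhibition, read by MTT assay, with a stated time of 72 h (a lower number here means a stronger inhibitor, a higher number a weaker inhibitor), compound 1 `C#CCSc1nc(Nc2cccc(Cl)c2)c(C#N)c(-c2ccccc2)n1` gives 10500 nM; it differs from the other two compounds in more than one place, so no single step to it can be read. Compound 2 `N#Cc1c(Nc2ccc(Cl)cc2)nc(SCc2cn(Cc3ccccc3Cl)nn2)nc1-c1ccccc1` gives 1590 nM in this assay, and compound 3 `N#Cc1c(Nc2cccc(Cl)c2)nc(SCc2cn(Cc3ccccc3Cl)nn2)nc1-c1ccccc1` gives 3590 nM. Among the measured compounds shown here, the only step between measured compounds that differ in a single place is a 2.3-fold higher number from compound 2 to compound 3 (0.35 log units; beyond the scatter), modest but beyond the scatter. Compound 3 thus stands second highest of the three numbers: compound 2 is the nearest, with its lower number, and compound 1 the furthest, with a number higher than that of compound 3.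

Compound 4 `N#Cc1c(Nc2ccc(F)cc2)nc(SCc2cn(Cc3ccccc3Cl)nn2)nc1-c1ccccc1` is not yet measured. It differs from compound 3 in one place: 4-fluorophenyl in place of 3-chlorophenyl on a nitrogen on an aromatic ring. For the measured compounds named here, the one measured step that bears on this change is a 2.3-fold higher number from compound 2 to compound 3 (0.35 log units; beyond the scatter), where 3-chlorophenyl replaced 4-chlorophenyl on the same nitrogen and the number rose. Returning to a ring substituted as in compound 2 would, on that step alone, be expected to lower the number again; the exchange of chlorine for fluorine has no measured counterpart here, so its contribution is unknown. The step of a 1.8-fold lower number from compound 3 to compound 4 (0.25 log units; within the scatter) is therefore expected to be downward and of roughly the size of a 2.3-fold higher number from compound 2 to compound 3 (0.35 log units; beyond the scatter), with widened uncertainty. Compound 4 is estimated at 2000 nM, within a range of 900 nM to 4500 nM.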

Compound 4, half-maximal inhibitory concentration: 5340 nM
For compound 4 the middle estimate is 2.7-fold (0.43 log units) below the measured one; measured number outside the range, above it.
By their numbers in this assay, from the lowest: compound 2; then compounds 3, 4 and 1 (each within the scatter of the next, the first and the last beyond it).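

In this assay, among these compounds, the step with fluoro in place of chloro on an aromatic carbon, a 3.4-fold higher number from compound 2 to compound 4 (0.53 log units; beyond the scatter), gives the first reading of a halogen exchange, and it is modest but beyond the scatter. The change from 3-chlorophenyl to 4-fluorophenyl on a nitrogen on an aromatic ring, a 1.5-fold higher number from compound 3 to compound 4 (0.17 log units; within the scatter), lies within the scatter, so these two groups cannot be told apart in this assay. Among the three groups compared at this place, 4-chlorophenyl is therefore the only one set apart from both others, and the 4-fluorophenyl of compound 4 shows that the substituent's place on the ring, shared with compound 2, does not by itself carry the lower number of compound 2.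

Nothing available here explains why chloro and fluoro part in this pair. Going by these compounds, compound 1 still differs from the others in more than one place, so its steps cannot be read, and it remains open whether a methoxy group or an amine in place of the halogen on this ring would stay with compound 2 or with compounds 3 and 4.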